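The source may report more compounds than this note shows. Statements on the series, on what has been measured and on what is new or still open speak of the compounds shown alone.

Measured so far in an assay on CHO cells for displacement of a labelled ligand from adenosine receptor A3 (Homo sapiens), read by scintillation counting, with a stated time of 3 h; on this read-out lower numbers stand for stronger inhibition and higher numbers for weaker inhibition:
- compound 1 `Cn1c(-c2cccc(Cl)c2)nc2c(NC3CCCC3)ncnc21` gives 514 nM
- compound 2 `Cn1c(-c2ccc(O)cc2)nc2c(NC3CCCC3)ncnc21` gives 521 nM
- compound 3 `Cc1cccc(-c2nc3c(NC4CCCC4)ncnc3n2C)c1` gives 510 nM

Compound 3 has the lowest of the three numbers, but the steps to it, a 1.0-fold lower number from compound 1 to compound 3 (0.00 log units; within the scatter) and a 1.0-fold lower number from compound 2 to compound 3 (0.01 log units; within the scatter), are both within the scatter, as is a 1.0-fold higher number from compound 1 to compound 2 (0.01 log units; within the scatter). On the numbers shown the three compounds are indistinguishable, and no order of potency among them can be read.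

Compound 4 `Cn1c(-c2ccc(Cl)cc2)nc2c(NC3CCCC3)ncnc21` has not been measured. The change from compound 3 is 4-chlorophenyl in place of 3-methylphenyl on an aromatic carbon. Within the data shown here, two measured steps bear on it. The exchange of chloro for methyl on the aryl group, from compound 1 to compound 3, gave a 1.0-fold lower number from compound 1 to compound 3 (0.00 log units; within the scatter); the exchange of the whole aryl group, 3-chlorophenyl for 4-hydroxyphenyl, from compound 1 to compound 2, gave a 1.0-fold higher number from compound 1 to compound 2 (0.01 log units; within the scatter). Neither a change of the substituent nor a change of its position on the phenyl has moved this assay beyond the scatter in this set. Compound 4 is therefore expected to give a number close to that of compound 3, with the step of a 1.0-fold higher number from compound 3 to compound 4 (0.01 log units; within the scatter) expected to stay within the scatter. The estimate for compound 4 is 520 nM, with a range of 250 nM to 1100 nM.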

Compound 4, inhibition constant: 1210 nM
Beside the measured number, compound 4's estimate is 2.3-fold (0.37 log units) below it; measured number outside the range, above it.
By their numbers in this assay, from the lowest: compounds 3, 1 and 2 (each within the scatter of the next); then compound 4.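

In this assay, among these compounds, the aryl group on this aromatic carbon now shows a step beyond the scatter, though a modest one, with 4-chlorophenyl as the only group so far to separate from the others: a 2.4-fold higher number from compound 3 to compound 4 (0.38 log units; beyond the scatter), a 2.4-fold higher number from compound 1 to compound 4 (0.37 log units; beyond the scatter) and a 2.3-fold higher number from compound 2 to compound 4 (0.37 log units; beyond the scatter). The step from 3-chlorophenyl to 4-chlorophenyl keeps the substituent and changes only its place on the phenyl, so that place can matter here, while the step from hydroxy to chloro shows that the substituent can matter as well; neither chloro alone nor substitution at the place it holds in 4-chlorophenyl goes with the higher number, as compound 1 carries chloro and compound 2 carries 4-hydroxyphenyl, and both stay within the scatter of compound 3. Nothing available explains this separation.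

Open, from the compounds shown here alone, is whether 4-methylphenyl, 4-methoxyphenyl or 4-aminophenyl would sit with compound 4 or with compound 2, and how a phenyl with no substituent compares. Also open, going by these compounds, is whether the separation of 4-chlorophenyl survives a longer chain in place of the methyl group on the shared core.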